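This account rests on a few compounds, and the source may have more. Where it says the series, first, only, none or still open, it means among the compounds named here.

Measured so far:
compound 1, `Cc1ccc(CNC(=O)n2c(N)nc3ccccc32)cc1`: 7 nM
compound 2, `Cc1nc2ccccc2n1C(=O)NCCCCc1ccccc1`: 1 nM

Both numbers come from an assay on HEK293 cells for inhibition of acid ceramidase (Homo sapiens), read by fluorescence, with stated times of 30 min and 1 h; a higher number here means a weaker inhibitor, a lower number a stronger inhibitor. Compound 1 gives the higher of these two numbers, and compound 2 the lower; the gap between them lies beyond the usual scatter of repeated measurements. Within the data shown here, the two compounds differ in more than one place, so no single step between them is counted, and only what their two values show can be said.

Compound 3, `Nc1nc2ccccc2n1C(=O)NCc1ccccc1`, has not yet been measured in this assay. It differs from compound 1 in one place: hydrogen in place of methyl on an aromatic carbon. Among the measured compounds shown here, no measured pair shows this change on its own, so its effect can only be expected, not read off. Compound 3 is expected to give a step of a 2.0-fold higher number from compound 1 to compound 3 (0.30 log units; within the scatter), small and, if anything, toward a higher number. Compound 3 is therefore estimated at 14 nM, with a range from 4 nM to 50 nM.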

Compound 3, half-maximal inhibitory concentration in the acid ceramidase assay: 29.3 nM
Compound 3: middle estimate off by 2.1-fold (0.32 log units), on the low side, and the stated range covers the measured number.
By their numbers in the acid ceramidase assay, from the lowest: compound 2; then compound 1; then compound 3.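

Going from 4-methylphenyl to phenyl, with hydrogen in place of methyl para to a large group, gives in the acid ceramidase assay a 4.2-fold higher number from compound 1 to compound 3 (0.62 log units; beyond the scatter), the first single change here that can be read on its own, with compound 1 at 7 nM and compound 3 at 29.3 nM, and it shows that this position is not indifferent to the small methyl group. The same change gives in a physicochemical assay for metabolic stability, read by HPLC, at pH 4.5, tested at 10 uM (a higher number here means that the compound lasts longer, a lower number that the compound disappears faster), a 1.2-fold higher number from compound 1 to compound 3 (0.09 log units; within the scatter), with compound 1 at 0.567 h and compound 3 at 0.7 h, so in this pair only the inhibition read-out shows a step beyond the scatter. Nothing at hand explains the step in inhibition.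

The compounds shown compare only hydrogen and methyl at this position, so how an ethyl group, a methoxy group or a chlorine atom there would read stays open. Also open, going by these compounds, is whether the same step would appear with the longer chain of compound 2, which differs from compound 1 in more than one place.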